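Fluoro in Place of Methoxy: What Compound 4 Should Show

A few compounds are considered here, and "the series" means these few. Any claim that something is new, unique, unknown or untested is made for them only; others in the source may bear on it.

Compound 1 `Nc1cc(N)c2nc(-c3ccccc3)c(NCc3ccc(Cl)c(Cl)c3)nc2c1`, in a functional assay on MDA-MB-435 cells (Homo sapiens) for inhibition, read by sulforhodamine B assay, with a stated time of 48 h; a lower number here means that less compound is tolerated, a higher number that more compound is tolerated: 52500 nM.
Compound 2 `CCOC(=O)[C@H](CCC(=O)O)NC(=O)c1ccc(Oc2nc3cc(N)cc(N)c3nc2-c2ccccc2)cc1`, in this assay: < 100000 nM, a limit of the assay rather than a number.
Compound 3 `COc1ccc(Sc2nc3cc(N)cc(N)c3nc2-c2ccccc2)cc1`, in this assay: < 100000 nM, again a limit, not a number.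

Compound 3 therefore stands at a limit in this assay, and only compound 1 gives an actual number. Two of the three values sit at the same limit (the limit of < 100000 nM in this assay, at which 2 of the 3 values shown sit).

Compound 4 `Nc1cc(N)c2nc(-c3ccccc3)c(Sc3ccc(F)cc3)nc2c1` differs from compound 3 by fluoro in place of methoxy on an aromatic carbon. Going by the values given here, no measured pair on this shared core shows this change, so there is no step to lean on. The expected change in this assay is none beyond the usual scatter, in either direction. Compound 4 is expected to give 60000 nM, within 20000 nM to 150000 nM. The expected step is a step that the limit leaves unreadable from compound 3 to compound 4.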

Compound 4, concentration lethal to 50% of the cells: 66100 nM
Estimate against measurement, compound 4: 1.1-fold (0.04 log units) below, within the range that was stated.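

Going by these compounds alone, compound 3 carries only a limit of the assay, not a number, and no step from it to compound 4 can be read. The compounds shown leave open whether fluoro in place of methoxy changes the result in this assay at all.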